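Aryl Swap to Methyl on a Dithiazole Core

The source may report more compounds than this note shows. Statements on the series, on what has been measured and on what is new or still open speak of the compounds shown alone.

Measured compounds:
Compound 1, `c1ccc(/N=c2\ssnc2-c2ccccc2)cc1` — 0%
Compound 2, `c1ccc(/N=c2\ssnc2-c2ccco2)cc1` — 0%
Compound 3, `c1ccc(/N=c2\ssnc2-c2cccs2)cc1` — 0%

Three compounds share one core and differ only in the group on one aromatic carbon. In a functional assay on MDA-MB-231 cells (Homo sapiens) for antiproliferative activity, read by MTT assay, with a stated time of 72 h, tested at 10 uM (on this read-out higher numbers stand for more inhibition at the one concentration tested (going by the name of the read-out) and lower numbers for less inhibition), compound 1 gives 0%, compound 2 gives 0%, and compound 3 gives 0%. Compound 3 therefore stands level with compound 1 and compound 2 at the digits shown; its step from compound 1 is no change at the digits printed from compound 1 to compound 3 (within the scatter), and that from compound 2 is no change at the digits printed from compound 2 to compound 3 (within the scatter). The remaining measured step, no change at the digits printed from compound 1 to compound 2 (within the scatter), tells the same story: exchanging phenyl, furan-2-yl and thiophen-2-yl at this carbon produced no movement beyond the scatter.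

Compound 4, `Cc1nss/c1=N\c1ccccc1`, has not yet been measured. It differs from compound 3 in one place: methyl in place of thiophen-2-yl on an aromatic carbon. All three measured steps change the group at this same aromatic carbon, and each was within the scatter, so the shift to methyl is expected to behave alike in this assay. The step from compound 3 to compound 4 is expected to be a number 2 percentage points higher from compound 3 to compound 4 (within the scatter), that is, no movement beyond the scatter. Compound 4 is accordingly estimated at 2%, with a range from -8% to 14%.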

Compound 4, a percentage reported as inhibition, at one concentration (the size of the read-out at that concentration, not a potency): 0%
The estimate for compound 4 lay 2 percentage points above the measured number, and the stated range covers the measured number.
By their numbers in this assay, from the lowest: compounds 1, 2, 3 and 4 (each within the scatter of the next).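

Until compound 4, every group at this carbon, next to the ring nitrogen, was an aromatic ring, so the flat read-out had been seen only among groups of that kind. In this assay the read-out stays just as flat with methyl, which carries no ring, whichever group it replaces: thiophen-2-yl (no change at the digits printed from compound 3 to compound 4 (within the scatter)), furan-2-yl (no change at the digits printed from compound 2 to compound 4 (within the scatter)) or phenyl (no change at the digits printed from compound 1 to compound 4 (within the scatter)). Across these four compounds, then, neither having an aromatic ring at this position nor the size of the group shows any link with the read-out, and no measurement at hand explains the flat result.

On these data alone, with all four compounds level, the series gives no sign of which change at this carbon, if any, would move the read-out, so whether an amine, a carboxylic acid or a longer chain there would do so stays open. Also open, as far as these compounds go, is whether a chlorine or a methoxy group on the phenyl ring of the shared core would bring any inhibition at all in this assay at the concentration tested.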